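Aortic relaxation series: cyanoguanidine aryl swap on compound 1

The compounds below may be only part of what the source reports. "The series", "measured", "known", "first", "only" and "open" are said of these compounds alone.

Measured compounds:
- compound 1 `CC1(C)Oc2ccc(C#N)cc2[C@@H](/N=C(\NC#N)Nc2ccc(Cl)cc2)[C@@H]1O`: 1800 nM
- compound 2 `C/N=C(\NC#N)N[C@@H]1c2cc(C#N)ccc2OC(C)(C)[C@H]1O`: 200 nM
- compound 3 `CC1(C)Oc2ccc(C#N)cc2[C@@H](n2cc(C#N)c3ccccc32)[C@@H]1O`: 2200 nM

All three share the same core and were run in a functional assay (aorta) with Rattus norvegicus as the target; a higher number here means a weaker inhibitor, a lower number a stronger inhibitor. Compound 1 stands second highest of the three numbers. Its nearest neighbour is compound 3, whose value of 2200 nM lies within the usual scatter of compound 1, so no order can be read between these two. Compound 2 is the one that stands apart: its value of 200 nM lies beyond the scatter below compound 1, and that gap is the only clear difference among the measured compounds.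

The next compound keeps the cyanoguanidine of compound 1 and changes only the aryl group on the amine nitrogen. Compound 4 `CC(=O)c1cccc(N/C(=N/[C@@H]2c3cc(C#N)ccc3OC(C)(C)[C@H]2O)NC#N)c1` differs from compound 1 in one place: 3-acetylphenyl in place of 4-chlorophenyl on an amine nitrogen.

Among the compounds with values here, no measured step of this kind exists, so the expectation rests on compound 1 alone. The step from compound 1 to compound 4 is expected to be small, a 1.4-fold higher number from compound 1 to compound 4 (0.14 log units; within the scatter), most likely within the scatter or somewhat toward a higher number. For compound 4 in this assay the estimate is 2500 nM, with a range from 800 nM to 8000 nM.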

Compound 4, half-maximal inhibitory concentration: 8400 nM
For compound 4 the middle estimate is 3.4-fold (0.53 log units) below the measured one; the whole stated range lies below it.
By their numbers in this assay, from the lowest: compound 2; then compounds 1 and 3 (each within the scatter of the next); then compound 4.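

In this assay, within the data shown here, the aryl group on the amine nitrogen of the cyanoguanidine gives the first single-place step: 3-acetylphenyl in place of 4-chlorophenyl produces a 4.7-fold higher number from compound 1 to compound 4 (0.67 log units; beyond the scatter), a modest step beyond the scatter. Among these compounds, this position is therefore sensitive to the aryl group, although only one step supports that reading. Nothing at hand bears on why the number moves.

This single step swaps one substituted aryl group for another, so it leaves open whether the loss of the chlorine or the entry of the acetyl group carries the change. A plain phenyl on the same nitrogen would help separate the two, while a pyridyl group would test whether the position tolerates a different ring.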